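Amine substituent on the furan-ring nitrogen of the shared core

The source may report more compounds than this note shows. Statements on the series, on what has been measured and on what is new or still open speak of the compounds shown alone.

Measured so far in a functional assay on HEK293 cells for agonist activity at Toll-like receptor 8 (Homo sapiens), read by reporter gene assay; a lower number here means that less compound is needed, a higher number that more compound is needed for the effect:
compound 1 `CCCCNc1oc2c(C)ncc(CO)c2c1Nc1ccccn1` gives 9380 nM
compound 2 `Cc1ncc(CO)c2c(Nc3ccccn3)c(NCCC(=O)OC(C)(C)C)oc12` gives 7640 nM
compound 3 `Cc1ncc(CO)c2c(Nc3ccccn3)c(NC3CCCCC3)oc12` gives 6930 nM

Compound 3 stands at the lowest of the three numbers, but none of the three is separated from another beyond the scatter: the step of a 1.4-fold lower number from compound 1 to compound 3 (0.13 log units; within the scatter) and the step of a 1.1-fold lower number from compound 2 to compound 3 (0.04 log units; within the scatter) are both small, as is the step of a 1.2-fold lower number from compound 1 to compound 2 (0.09 log units; within the scatter) between the other two. Exchanging butyl for cyclohexyl, or for a chain carrying a tert-butoxycarbonyl, has left this assay essentially unchanged.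

Compound 4 `Cc1ncc(CO)c2c(Nc3ccccn3)c(NC(C)(C)C)oc12` differs from compound 3 in one place: tert-butyl in place of cyclohexyl on a nitrogen on an aromatic ring. For the measured compounds named here, of the measured steps, the one from compound 1 to compound 3 bears most directly on it, since it also exchanges one saturated carbon group for another on the same nitrogen; the step from compound 2 to compound 3 does the same with a longer chain. Both were within the scatter, so no step beyond the scatter is expected here either, in either direction: the expected step is a 1.2-fold higher number from compound 3 to compound 4 (0.06 log units; within the scatter).

Compound 4 is therefore estimated in this assay at 8000 nM, with a range from 3000 nM to 22000 nM.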

Compound 4, half-maximal effective concentration: "not active" (no number reported)
The entry for compound 4 holds no number; there is nothing to compare the estimate with.
By their numbers in this assay, from the lowest: compounds 3, 2 and 1 (each within the scatter of the next).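

In this assay, for the compounds shown here, compound 4 is recorded as "not active" with no number, so no step from compound 3 to compound 4 can be read. The compounds shown leave open whether tert-butyl in place of cyclohexyl on this nitrogen separates compound 4 from compound 3, and by how much. No measurement shown accounts for this entry.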